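The source may hold more compounds than are shown below. What is called first, only, known or untested is meant among the compounds shown, and "the series" means these compounds.

In a functional assay on HeLa cells (Homo sapiens) for antiproliferative activity, read by MTT assay, with a stated time of 48 h (on this read-out lower numbers stand for stronger inhibition and higher numbers for weaker inhibition), compound 2 `Clc1ccc(-c2nn(-c3ccccc3)cc2-c2nc3cc(Cl)ccc3[nH]2)cc1` gives 1630 nM and compound 1 `FC(F)(F)c1ccc2[nH]c(-c3cn(-c4ccccc4)nc3-c3ccccc3)nc2c1`, which carries trifluoromethyl, gives 1920 nM. These two numbers lie within the usual scatter of each other, so neither stands apart. Going by the values given here, compound 3 `FC(F)(F)c1ccc2[nH]c(-c3cn(-c4ccccc4)nc3-c3ccc(Cl)cc3)nc2c1` has trifluoromethyl in place of chloro on an aromatic carbon, the one change that separates it from compound 2 (trifluoromethyl in place of chloro on an aromatic carbon). Among the compounds with values here, no measured pair shows this change alone, and no step beyond the scatter is expected in this assay. The estimated step is a 1.1-fold lower number from compound 2 to compound 3 (0.04 log units; within the scatter). For compound 3 the expected value is 1500 nM, within an estimated range of 600 nM to 3800 nM.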

Compound 3, half-maximal inhibitory concentration: 4420 nM
Compound 3: the middle estimate sits 2.9-fold (0.47 log units) below what was measured; measured number above the stated range.
By their numbers in this assay, from the lowest: compounds 2 and 1 (each within the scatter of the next); then compound 3.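

In this assay, going by these compounds alone, the group at this position on the fused ring does matter: trifluoromethyl in place of chloro gives a 2.7-fold higher number from compound 2 to compound 3 (0.43 log units; beyond the scatter) and so weaker inhibition, which no earlier pair could show. Chloro in place of hydrogen on an aromatic carbon gives a 2.3-fold higher number from compound 1 to compound 3 (0.36 log units; beyond the scatter) and so also weaker inhibition, with trifluoromethyl present on the fused ring. No measurement at hand explains either step. Going by these compounds, whether an amine or a methoxy group at this position would give stronger or weaker inhibition than chloro stays open. So does how a hydrogen there would compare.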